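Replacing difluoromethoxy with isobutyl in a small series

This account rests on a few compounds, and the source may have more. Where it says the series, first, only, none or still open, it means among the compounds named here.

In a functional assay on MCF7 cells (Homo sapiens) for antiproliferative activity, read by sulforhodamine B assay, with a stated time of 48 h (a higher number here means a weaker inhibitor, a lower number a stronger inhibitor), compound 3 `O=C1NCCN1c1ccc(S(=O)(=O)Nc2ccc(OC(F)F)cc2)cc1` gives 760 nM as its half-maximal inhibitory concentration. That number lies within the usual scatter of its two measured relatives, since compound 1 `Cc1ccc(NS(=O)(=O)c2ccc(N3CCNC3=O)cc2)cc1` gives 610 nM and compound 2 `O=C1NCCN1c1ccc(S(=O)(=O)Nc2ccccc2)cc1` gives 470 nM in the same test.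

The next structure is compound 4 `CC(C)Cc1ccc(NS(=O)(=O)c2ccc(N3CCNC3=O)cc2)cc1`, which has isobutyl in place of difluoromethoxy on an aromatic carbon, para to a large group (isobutyl in place of difluoromethoxy on an aromatic carbon). Three measured steps swap the group at this same place, and all of them stay small: a 1.3-fold lower number from compound 1 to compound 2 (0.11 log units; within the scatter) and a 1.2-fold higher number from compound 1 to compound 3 (0.10 log units; within the scatter) and a 1.6-fold higher number from compound 2 to compound 3 (0.21 log units; within the scatter) are the whole record. Hydrogen, methyl and difluoromethoxy therefore give numbers that cannot be told apart, although no measured compound carries isobutyl, so this remains an extrapolation.

An estimated step of a 1.3-fold lower number from compound 3 to compound 4 (0.10 log units; within the scatter) is expected in this assay with no clear direction and no shift beyond the scatter. For compound 4 the expected value is 600 nM with an estimated range from 250 nM to 1500 nM for the coming measurement.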

Compound 4, half-maximal inhibitory concentration: > 1000 nM
Compound 4: no number, only a limit; the forecaster's own chance of this, stated with the estimate: 2%; middle value at least 1.6-fold (0.22 log units) away from the limit.
By their numbers in this assay, from the lowest: compounds 2, 1 and 3 (each within the scatter of the next). At a limit, above all of these: compound 4.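

In this assay compound 4 gives > 1000 nM, which is a limit and not a number: the limit of > 1000 nM in this assay, at which 1 of the 4 values shown sits.

Hydrogen, methyl and difluoromethoxy could not be told apart on this aromatic carbon, para to a large group, but isobutyl gives the only step at this place that passes the scatter, an at least 2.1-fold higher number from compound 2 to compound 4 (0.32 log units; beyond the scatter). Against the other two relatives the floor settles nothing, with an at least 1.3-fold higher number from compound 3 to compound 4 (0.11 log units; that floor lies within the scatter) and an at least 1.6-fold higher number from compound 1 to compound 4 (0.21 log units; that floor lies within the scatter), so isobutyl may or may not truly separate from difluoromethoxy and methyl.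

As far as these compounds go, how far compound 4 really lies from its relatives stays open. Also open, from the compounds shown here alone, is how an amine, a carboxylic acid or a longer chain at this place would read, and whether ethyl, a shorter chain than isobutyl, would already separate from hydrogen.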